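The source may report more compounds than this note shows. Statements on the series, on what has been measured and on what is new or still open speak of the compounds shown alone.

Of the compounds shown here, two of a shared core have been measured in an assay for inhibition of Polyunsaturated fatty acid 5-lipoxygenase (Homo sapiens), read by spectrophotometry, tested at 10 uM, in the presence of a further agent that is not named here; a lower number here means less inhibition, a higher number more inhibition at the concentration tested (going by the name of the read-out). Compound 1 `Cc1ccc(/C=C/C(=O)c2sc(NC(=O)c3ccc(F)cc3)nc2C)cc1` gives 91.5% in this assay. Compound 2 `Cc1nc(NC(=O)c2ccccc2)sc1C(=O)/C=C/c1cccs1` gives 71.9% in this assay, which places it lowest of the two numbers; its nearest neighbour is compound 1, whose number stands higher by a gap that lies beyond the usual scatter. Among the measured compounds shown here, the two compounds differ in more than one place, so their values show only the combined effect of those changes, and no single step between them can be read off.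

Compound 3 `Cc1nc(NC(=O)c2ccc(F)cc2)sc1C(=O)/C=C/c1cccs1` has not yet been measured in this assay. It differs from compound 2 in one place: fluoro in place of hydrogen on an aromatic carbon. Compound 1 also carries a fluoro group on its six-membered aromatic ring of carbon only, but it differs from compound 3 elsewhere as well, so no clean reading of this change is available from the measured pair.

On this basis compound 3 is expected to move from compound 2 by a step of a number 6.1 percentage points higher from compound 2 to compound 3 (within the scatter) in this assay, which is small and within the scatter. Compound 3 is estimated to give 78% in this assay, with a likely range from 62% to 92%.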

Compound 3, a percentage reported as inhibition, at one concentration (the size of the read-out at that concentration, not a potency): 81.7%
The estimate for compound 3 lay 3.7 percentage points below the measured number; measured number inside the range.
By their numbers in this assay, from the lowest: compounds 2, 3 and 1 (each within the scatter of the next, the first and the last beyond it).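

The phenyl to 4-fluorophenyl change, on an aromatic carbon para to a large group, can now be read on its own in this assay: fluoro in place of hydrogen gives a number 9.8 percentage points higher from compound 2 to compound 3 (within the scatter) and so leaves the number unchanged within the usual scatter. Among the compounds shown here, with the fluoro group held in place, the change of 4-methylphenyl to thiophen-2-yl on the double-bonded chain can also be read for the first time, and it gives a number 9.8 percentage points lower from compound 1 to compound 3 (within the scatter) with no change beyond the scatter either. Each of these two changes, taken singly, therefore stays within the scatter in this assay and neither one stands out as a clear step at this level of inhibition.

From the compounds shown here alone, it remains open whether a different group at this position, such as chloro, methoxy or an amine, would shift the number beyond the scatter, and whether fluoro in place of hydrogen behaves the same way when 4-methylphenyl sits on the chain. No measurement beyond these inhibition numbers bears on either step.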